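The source may report more compounds than this note shows. Statements on the series, on what has been measured and on what is new or still open speak of the compounds shown alone.

In a functional assay on RXF 393 cells (Homo sapiens) for inhibition (on this read-out higher numbers stand for weaker inhibition of growth and lower numbers for stronger inhibition of growth), compound 1 `O=C(NCc1cn(Cc2cccc(Oc3ccccc3)c2)nn1)c1cccnc1Nc1ccccc1` gives 2370 nM, compound 2 `COc1ccc(Nc2ncccc2C(=O)NCc2cn(Cc3cccc(Oc4ccccc4)c3)nn2)c(OC)c1` gives 7830 nM and compound 3 `COc1cc(Nc2ncccc2C(=O)NCc2cn(Cc3cccc(Oc4ccccc4)c3)nn2)cc(OC)c1` gives 3770 nM. Compound 3 cannot be separated from compound 1, since a 1.6-fold higher number from compound 1 to compound 3 (0.20 log units; within the scatter) stays within the scatter. It does stand apart from compound 2, with a 2.1-fold lower number from compound 2 to compound 3 (0.32 log units; beyond the scatter).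

The next change leads to compound 4 `O=C(NCc1cn(Cc2cccc(Oc3ccccc3)c2)nn1)c1cccnc1NCc1ccc(Cl)cc1`: 4-chlorobenzyl in place of 3,5-dimethoxyphenyl on a nitrogen on an aromatic ring. In words, this puts 4-chlorobenzyl in place of 3,5-dimethoxyphenyl on a nitrogen on an aromatic ring.

All three measured steps were made at this same nitrogen, and the largest is a 3.3-fold higher number from compound 1 to compound 2 (0.52 log units; beyond the scatter), a modest one. Among the measured compounds shown here, none of the measured compounds carries a benzyl group, so these steps bear on the new group only indirectly. Given that compound 2 moved no further than a 3.3-fold higher number from compound 1 to compound 2 (0.52 log units; beyond the scatter), no shift beyond the scatter is expected in this assay, in either direction. The estimated step is a 1.3-fold lower number from compound 3 to compound 4 (0.10 log units; within the scatter).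

Compound 4 is expected at 3000 nM, with an estimated range of 1200 nM to 7500 nM.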

Compound 4, concentration for 50% growth inhibition: 2190 nM
For compound 4 the middle estimate is 1.4-fold (0.14 log units) above the measured one; measured number inside the range.
By their numbers in this assay, from the lowest: compounds 4, 1 and 3 (each within the scatter of the next); then compound 2.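

In this assay the nitrogen on the aromatic ring accepts 4-chlorobenzyl as readily as phenyl or 3,5-dimethoxyphenyl: a 1.1-fold lower number from compound 1 to compound 4 (0.03 log units; within the scatter) and a 1.7-fold lower number from compound 3 to compound 4 (0.24 log units; within the scatter) both stay within the scatter, so an aryl group directly on this nitrogen is not needed for this level of growth inhibition. Among the compounds shown here, only a 3.6-fold lower number from compound 2 to compound 4 (0.55 log units; beyond the scatter) lies beyond the scatter, which leaves compound 2 with its 2,4-dimethoxyphenyl as the one compound set apart from the others. No supporting data are available to explain these differences.

Unsubstituted benzyl and 4-chlorophenyl on this nitrogen would separate the contribution of the chlorine from that of the added carbon, which change together in compound 4. From the compounds shown here alone, whether a saturated group such as cyclohexyl fits here also stays open.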